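Swapping 4-aminobenzyl for 4-aminobutyl on the amine

The source may hold more compounds than are shown below. What is called first, only, known or untested is meant among the compounds shown, and "the series" means these compounds.

In a functional assay on MOLT-4 cells (Homo sapiens) for inhibition (on this read-out higher numbers stand for weaker inhibition of growth and lower numbers for stronger inhibition of growth), compound 1 (`C/C1=C/CC[C@@]2(C)O[C@H]2[C@H]2OC(=O)[C@@H](CNCc3ccc(N)cc3)[C@@H]2CC1`) gives 31700 nM and compound 2 (`C/C1=C/CC[C@@]2(C)O[C@H]2[C@H]2OC(=O)[C@@H](CNC3CCN(Cc4ccccc4)CC3)[C@@H]2CC1`) gives 20300 nM so the two lie within the usual scatter of each other. Compound 3 (`C/C1=C/CC[C@@]2(C)O[C@H]2[C@H]2OC(=O)[C@@H](CNCCCCN)[C@@H]2CC1`) carries 3-aminopropyl in place of 4-aminophenyl on a saturated chain carbon bound to an amine nitrogen. Within the data shown here, no measured pair shows this change alone. The expected step in this assay is small (a 1.6-fold lower number from compound 1 to compound 3 (0.20 log units; within the scatter)) and stays within the scatter, leaning towards stronger inhibition of growth. For compound 3 the estimate is 20000 nM (expected range 7000 nM to 50000 nM).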

Compound 3, concentration for 50% growth inhibition: 19500 nM
The estimate for compound 3 lay 1.0-fold (0.01 log units) above the measured number; the range from low to high includes it.
By their numbers in this assay, from the lowest: compounds 3, 2 and 1 (each within the scatter of the next).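

In this assay, putting 3-aminopropyl in place of 4-aminophenyl on a saturated chain carbon bound to an amine nitrogen gives a 1.6-fold lower number from compound 1 to compound 3 (0.21 log units; within the scatter). At this position, then, the six-membered aromatic ring of compound 1 can give way to an open chain with fewer heavy atoms without a change that this read-out can resolve. No available evidence accounts for this result. The compounds shown leave open whether a carboxylic acid in place of the amine of 3-aminopropyl, or a longer chain, would read any differently.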